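Working notes: one-carbon homologation from compound 3 to compound 4

The source may hold more compounds than are shown below. What is called first, only, known or untested is meant among the compounds shown, and "the series" means these compounds.

Measured in an assay on lysate from A-375 cells for inhibition of neutral ceramidase (Homo sapiens); a lower number here means a stronger inhibitor, a higher number a weaker inhibitor:
compound 1 `CCCCCCCCCCCC/C=C/[C@@H](O)[C@@H](C)NC(=O)CCCCCCC` gives 2000 nM
compound 2 `CCCCCCCCCCCC/C=C/[C@@H](O)[C@@H](C)NC(=O)c1ccc(CCCCCCC)cc1` gives 800 nM
compound 3 `CCCCCCCCCCCC/C=C/[C@@H](O)[C@@H](C)NC(=O)c1ccc(OCCCOCOC)cc1` gives 3600 nM

Among the compounds with values here, compound 3 carries the highest number of the three; its gap to compound 1 lies within the scatter, its gap to compound 2 beyond it, the only measured change on the aromatic carbon being a 4.5-fold higher number from compound 2 to compound 3 (0.65 log units; beyond the scatter). Compound 4 `CCCCCCCCCCCC/C=C/[C@@H](O)[C@@H](C)NC(=O)c1ccc(OCCCCOCOC)cc1` differs from compound 3 by (methoxymethoxy)methyl in place of methoxymethoxy on a saturated chain carbon, three bonds along the chain from an oxygen on an aromatic ring. Within the data shown here, no measured step is a single-carbon lengthening of a saturated chain; the step between compound 2 and compound 3 exchanged the whole group and serves only as a loose guide. In this assay compound 4 is therefore expected to stay close to compound 3, with an expected step of a 1.2-fold lower number from compound 3 to compound 4 (0.08 log units; within the scatter), within the scatter. The estimate for compound 4 is 3000 nM, range 1500 nM to 6500 nM.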

Compound 4, inhibition constant: 5400 nM
For compound 4 the middle estimate is 1.8-fold (0.26 log units) below the measured one, and the stated range covers the measured number.
By their numbers in this assay, from the lowest: compound 2; then compounds 1, 3 and 4 (each within the scatter of the next, the first and the last beyond it).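

In this assay, exchanging methoxymethoxy for (methoxymethoxy)methyl on this saturated chain carbon gives a 1.5-fold higher number from compound 3 to compound 4 (0.18 log units; within the scatter), so this change leaves the number within the scatter. The gap to the all-carbon group of compound 2 persists, with a 6.8-fold higher number from compound 2 to compound 4 (0.83 log units; beyond the scatter). Nothing available accounts for either step.

The compounds shown leave open whether 2-(methoxymethoxy)ethyl at this place would continue the same flat trend. They also leave open how an amine or a carboxylic acid at the chain end would compare with compound 2.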